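Solubility of a cyclobutyl hydroxamate compared with its open-chain parent

The source may hold more compounds than are shown below. What is called first, only, known or untested is meant among the compounds shown, and "the series" means these compounds.

Measured compounds:
compound 1, `O=C(N[C@H](CO)C(=O)NO)c1ccc(C#Cc2ccccc2)cc1`: 36000 nM
compound 2, `O=C(C[C@H](NC(=O)c1ccc(C#Cc2ccccc2)cc1)C(=O)NO)NCCCO`: 82000 nM

In a physicochemical assay for solubility (a lower number here means a less soluble compound, a higher number a more soluble compound), compound 1 gives 36000 nM, the lower of the two numbers in hand. Compound 2, in the same assay, gives 82000 nM, a gap beyond the usual scatter, so compound 1 stands as the less soluble of the pair.

Compound 3, `O=C(NC1(C(=O)NO)CCC1)c1ccc(C#Cc2ccccc2)cc1`, has not yet been measured in this assay. It differs from compound 1 in one place: a group of 8 heavy atoms (5 carbon, 1 nitrogen, 2 oxygen; one four-membered non-aromatic ring of carbon only) in place of a group of 7 heavy atoms (3 carbon, 1 nitrogen, 3 oxygen; no ring), on an amide-type nitrogen. Going by the values given here, no step between two measured compounds speaks to a change of this kind, so the expectation rests on compound 1 alone. The step from compound 1 to compound 3 is expected to be small, slightly downward, and likely within the scatter: a 1.4-fold lower number from compound 1 to compound 3 (0.16 log units; within the scatter). Compound 3 is therefore estimated at 25000 nM in this assay, with a range from 10000 nM to 60000 nM.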

Compound 3, solubility: 5000 nM
The estimate for compound 3 lay 5.0-fold (0.70 log units) above the measured number; measured number outside the range, below it.
By their numbers in this assay, from the lowest: compound 3; then compound 1; then compound 2.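

Putting 1-(hydroxycarbamoyl)cyclobutyl in place of the open-chain group on the amide-type nitrogen gives, in this assay, a 7.2-fold lower number from compound 1 to compound 3 (0.86 log units; beyond the scatter), a step beyond the scatter. Going by these compounds alone, the earlier compounds offered no step at this position, so this is the only direct reading of it, and it shows that the number responds to a change of group here. The change adds a four-membered carbon ring and removes a hydrogen-bond donor and acceptor all at once, and no measurement shown bears on the reason for the lower number.

The compounds shown leave open whether the cyclobutyl ring or the lost hydroxyl group accounts for the step. They also leave open how the number would move if an amine or a carboxylic acid were carried on the cyclobutyl ring.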